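The source may report more compounds than this note shows. Statements on the series, on what has been measured and on what is new or still open speak of the compounds shown alone.

In a physicochemical assay for solubility, with a stated time of 24 h, at pH 2.2 (a lower number here means a less soluble compound, a higher number a more soluble compound), compound 1 `O=C(NC[C@@H]1[C@H]2CN(C(=O)CCc3cc(Cl)cc(Cl)c3)C[C@@H]12)c1ccc2[nH]c(=O)oc2c1` gives < 1 ug/mL as a limit, not a number. Compound 2 `O=C(NC[C@@H]1[C@H]2CN(C(=O)NCc3cc(Cl)cc(Cl)c3)C[C@@H]12)c1ccc2[nH]c(=O)oc2c1` gives < 1 ug/mL, which is also a limit. Compound 3 `N#Cc1cc(COC(=O)N2C[C@@H]3[C@@H](CNC(=O)c4ccc5[nH]c(=O)oc5c4)[C@@H]3C2)cc(OC(F)(F)F)c1` gives < 1 ug/mL, again a limit. Compound 2 thus has no number of its own and shares the limit of < 1 ug/mL in this assay, at which 3 of the 3 values shown sit, with the others. For the measured compounds named here, the one measured step bearing on it is a step that the two limits leave unreadable from compound 1 to compound 2, so it offers no size to carry forward.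

Compound 4 `Cc1cc(COC(=O)N2C[C@@H]3[C@@H](CNC(=O)c4ccc5[nH]c(=O)oc5c4)[C@@H]3C2)no1` has not yet been measured. It carries (5-methyl-1,2-oxazol-3-yl)methoxy in place of (3,5-dichlorobenzyl)amino on a carbonyl carbon, and the count runs: (5-methyl-1,2-oxazol-3-yl)methoxy in place of (3,5-dichlorobenzyl)amino on a carbonyl carbon. Going by the values given here, no measured step has a readable size, so the expectation rests on this structural change alone and is tentative. An upward move in this assay is expected, and the estimated size is an at least 8.0-fold higher number from compound 2 to compound 4 (0.90 log units; beyond the scatter) from that limit. For compound 4 the expected value is 8 ug/mL in this assay, with an estimated range from 1.5 ug/mL to 50 ug/mL overall.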

Compound 4, solubility: > 86 ug/mL
Compound 4 ended at the assay's limit (the forecaster's own chance of this, stated with the estimate: 20%); at least 10-fold (1.03 log units) between middle value and limit.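

For the compounds shown here, at this carbonyl carbon, whose other neighbour is an amide-type nitrogen in a ring, the earlier compounds gave only limits, and the step between compound 1 and compound 2 cannot be read. The group placed here can nevertheless move the read-out strongly in this assay, with an at least 86-fold higher number from compound 2 to compound 4 (1.93 log units; beyond the scatter) and an at least 86-fold higher number from compound 1 to compound 4 (1.93 log units; beyond the scatter). Both steps are minimum sizes, and the result reaches the upper end of the values shown: the limit of > 86 ug/mL in this assay, at which 1 of the 4 values shown sits.

On these data alone, compound 4 gives > 86 ug/mL, which is a limit, so its actual solubility stays unknown. Also open, as far as these compounds go, is which part of the exchange carries the step, and whether a pyridine ring or a morpholine in place of (5-methyl-1,2-oxazol-3-yl)methoxy would give a value inside the limits of this assay.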